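Fluoro for trifluoromethyl on the pendant aryl ring

The source may report more compounds than this note shows. Statements on the series, on what has been measured and on what is new or still open speak of the compounds shown alone.

The two measured compounds share one core and differ only in the aryl group on a saturated ring carbon. Compound 1 `O=C1NC(=O)/C(=C\c2ccc(OCC(=O)N3N=C(c4ccc(F)cc4)CC3c3ccccc3Cl)cc2)S1` gives 1100 nM in an assay on cells for inhibition of histone deacetylase 4 (Homo sapiens), read by fluorescence, with a stated time of 30 min; a higher number here means a weaker inhibitor, a lower number a stronger inhibitor. Compound 2 `O=C1NC(=O)/C(=C\c2ccc(OCC(=O)N3N=C(c4ccc(F)cc4)CC3c3ccc(C(F)(F)F)cc3)cc2)S1` gives 1300 nM in this assay. The step of a 1.2-fold higher number from compound 1 to compound 2 (0.07 log units; within the scatter), so compound 2 has the higher of the two numbers, yet the two values cannot be told apart.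

Compound 3 `O=C1NC(=O)/C(=C\c2ccc(OCC(=O)N3N=C(c4ccc(F)cc4)CC3c3ccc(F)cc3)cc2)S1` is the unmeasured compound. It differs from compound 2 by fluoro in place of trifluoromethyl on an aromatic carbon. For the measured compounds named here, only the step from compound 1 to compound 2 bears on this: it also swapped the substituent pattern on the same aryl ring, and it was a 1.2-fold higher number from compound 1 to compound 2 (0.07 log units; within the scatter). The earlier change on this ring therefore left this assay unmoved, and the new change is of the same kind at the same place.

For compound 3 the expected step is a 1.1-fold lower number from compound 2 to compound 3 (0.03 log units; within the scatter), no movement beyond the scatter in either direction. Compound 3 is thus estimated at 1200 nM, with a range from 500 nM to 3000 nM.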

Compound 3, half-maximal inhibitory concentration: 1400 nM
Estimate against measurement, compound 3: 1.2-fold (0.07 log units) below, and the stated range covers the measured number.
By their numbers in this assay, from the lowest: compounds 1, 2 and 3 (each within the scatter of the next).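

Across the three compounds, the aryl group on the saturated ring carbon now carries three different substituent patterns, and this assay does not separate them. Fluoro in place of trifluoromethyl on an aromatic carbon, para to a large group, gives a 1.1-fold higher number from compound 2 to compound 3 (0.03 log units; within the scatter), so going from a substituent of four heavy atoms to one of a single heavy atom leaves the number where it was. The comparison of 4-fluorophenyl with 2-chlorophenyl gives a 1.3-fold higher number from compound 1 to compound 3 (0.10 log units; within the scatter), which adds that this pair, like the pair compared earlier, cannot be told apart, so all three aryl groups on this carbon read alike in this assay; no measurement on hand speaks to why these numbers stay together.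

The substituents shown on this aryl ring are only chloro, fluoro and trifluoromethyl, so it remains open whether an amine, a carboxylic acid or a longer alkyl chain at this place would also leave the number unmoved. Also open, going by these compounds, is whether the 4-fluorophenyl group on the other side of the shared core tolerates such changes equally, since it stays the same in all three compounds.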